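The compounds below may be only part of what the source reports. "The series", "measured", "known", "first", "only" and "open" are said of these compounds alone.

Among the compounds with values here, compound 1 `COc1ncnc2c1c(-c1cccs1)cn2[C@@H]1O[C@H](CO)[C@@H](O)[C@H]1O` is the only compound here with an actual number: in a functional assay on HCT-116 cells (Homo sapiens), read by MTT assay, with a stated time of 72 h (a higher number here means a weaker inhibitor, a lower number a stronger inhibitor), compound 1 gives 440 nM. Compound 2 `CSc1ncnc2c1c(-c1cccs1)cn2[C@@H]1O[C@H](CO)[C@@H](O)[C@H]1O` differs only by methylsulfanyl in place of methoxy on an aromatic carbon, and in this assay compound 2 reaches only a limit, > 20000 nM. That step, an at least 45-fold higher number from compound 1 to compound 2 (1.65 log units; beyond the scatter), rests on (the limit of > 20000 nM in this assay, at which 1 of the 2 values shown sits), so its true size is not known.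

Compound 3 `C#Cc1cn([C@@H]2O[C@H](CO)[C@@H](O)[C@H]2O)c2ncnc(OC)c12` keeps the methoxy of compound 1 and changes a different position: ethynyl in place of thiophen-2-yl on an aromatic carbon. The one measured step touches the methoxy position, not the aromatic carbon where the thiophen-2-yl sits, so no shown step bears directly on this change. With nothing measured at this position, a modest shift in either direction in this assay seems as likely as none beyond the scatter. Compound 3 is therefore expected to give about 600 nM, between 100 nM and 4000 nM, which would mean a step of a 1.4-fold higher number from compound 1 to compound 3 (0.13 log units; within the scatter).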

Compound 3, half-maximal inhibitory concentration: 5140 nM
Compound 3: middle estimate off by 8.6-fold (0.93 log units), on the low side; the whole stated range lies below it.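

The aromatic carbon bearing the thiophen-2-yl had no measured change until now, and in this assay it proves sensitive: ethynyl in its place gives a 12-fold higher number from compound 1 to compound 3 (1.07 log units; beyond the scatter). Compound 3 keeps the methoxy and the rest of compound 1, so this large step belongs to this one place, and the methoxy position is not the only part of the molecule where a single change counts. Nothing measured here explains why the step is this large.

This change removes a ring and replaces the group with a smaller one at the same time, so the pair cannot say which of the two matters. On these data alone, a phenyl ring or a propyl chain at this position could separate the two, and how ethynyl behaves with methylsulfanyl in place of methoxy stays open.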